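A few compounds are considered here, and "the series" means these few. Any claim that something is new, unique, unknown or untested is made for them only; others in the source may bear on it.

In a functional assay on HUVEC cells (Homo sapiens) for inhibition, with a stated time of 4 days (a lower number here means a stronger inhibitor, a higher number a weaker inhibitor), compound 1 `COc1ccc(C(=O)O)cc1COc1ccc(Cl)c(C)c1` gives only a limit, > 50000 nM. Among the compounds with values here, compound 2 `COC(=O)c1ccc(OC)c(COc2ccc(Cl)c(C)c2)c1` gives 2300 nM, the only actual number so far. Compound 3 `COc1ccc(C#N)cc1COc1ccc(Cl)c(C)c1` differs from it by cyano in place of methoxycarbonyl on an aromatic carbon. Within the data shown here, one measured step bears on this, at the same aromatic carbon: an at least 21-fold lower number from compound 1 to compound 2 (1.33 log units; beyond the scatter), a large step whose open end is the limit of > 50000 nM in this assay, at which 1 of the 2 values shown sits. That step does not involve cyano, so it gives neither size nor direction for this change. The expected step is a 1.3-fold higher number from compound 2 to compound 3 (0.12 log units; within the scatter), with none beyond the scatter anticipated. For compound 3 the estimate is 3000 nM, with an expected range of 800 nM to 12000 nM.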

Compound 3, half-maximal inhibitory concentration: 1500 nM
The estimate for compound 3 lay 2.0-fold (0.30 log units) above the measured number; the measured number falls inside the stated range.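

In this assay, the carbon para to a methoxy group accepts cyano in place of methoxycarbonyl, with a 1.5-fold lower number from compound 2 to compound 3 (0.19 log units; within the scatter), so a carbonyl at this carbon is not required at this level of activity. Replacing carboxy with cyano gives an at least 33-fold lower number from compound 1 to compound 3 (1.52 log units; beyond the scatter), a second large step from compound 1. The true size of that step remains unknown: the limit of > 50000 nM in this assay, at which 1 of the 3 values shown sits.

From the compounds shown here alone, whether a primary amide or an aminomethyl group at this carbon would stay close to compound 2 and compound 3 remains open. The shared core is also untested with other substituents at this carbon.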